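Adding a second phenyl on the chain carbon

The compounds below may be only part of what the source reports. "The series", "measured", "known", "first", "only" and "open" are said of these compounds alone.

Measured compounds:
Compound 1, `C=CCn1c[n+](C/C=C(\C)CC/C=C(\C)CC/C=C(\C)CCC=C(C)C)c2/c(=N/OC)[nH]cnc21`: 4610 nM
Compound 2, `CO/N=c1\[nH]cnc2c1[n+](C/C=C(\C)CC/C=C(\C)CC/C=C(\C)CCC=C(C)C)cn2Cc1ccccc1`: 3400 nM

In a functional assay on ACHN cells (Homo sapiens) for cytotoxicity (a lower number here means a stronger inhibitor, a higher number a weaker inhibitor), compound 1 gives 4610 nM, and compound 2 gives 3400 nM. Going by the values given here, the single step between them, a 1.4-fold lower number from compound 1 to compound 2 (0.13 log units; within the scatter), is phenyl in place of vinyl on a saturated chain carbon bound to an aromatic nitrogen. Among the compounds with values here, compound 2 thus holds the lower of the two numbers, but its only neighbour, compound 1, lies within the scatter of it, so no order between the two can be claimed.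

Compound 3, `CO/N=c1\[nH]cnc2c1[n+](C/C=C(\C)CC/C=C(\C)CC/C=C(\C)CCC=C(C)C)cn2C(c1ccccc1)c1ccccc1`, differs from compound 2 by phenyl in place of hydrogen on a saturated chain carbon bound to an aromatic carbon and an aromatic nitrogen. Within the data shown here, the one measured step that touches the same carbon, a 1.4-fold lower number from compound 1 to compound 2 (0.13 log units; within the scatter), was itself too small to rise above the scatter; nothing measured here speaks for a large move in either direction when a second phenyl enters on that carbon. Compound 3 is therefore expected to give about 3000 nM in this assay, in a range from 1200 nM to 7500 nM, the expected step being a 1.1-fold lower number from compound 2 to compound 3 (0.05 log units; within the scatter).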

Compound 3, half-maximal inhibitory concentration: 4750 nM
Beside the measured number, compound 3's estimate is 1.6-fold (0.20 log units) below it; the measured number falls inside the stated range.
By their numbers in this assay, from the lowest: compounds 2, 1 and 3 (each within the scatter of the next).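

In this assay, the entry of phenyl in place of hydrogen on a saturated chain carbon bound to an aromatic carbon and an aromatic nitrogen comes with a 1.4-fold higher number from compound 2 to compound 3 (0.15 log units; within the scatter) and so does not separate compound 3 from compound 2. The earlier step, a 1.4-fold lower number from compound 1 to compound 2 (0.13 log units; within the scatter), had exchanged one group on this carbon for another; this result adds that a further phenyl, with its 6 heavy atoms, also leaves the number within the scatter, so no step at this carbon among the compounds shown rises above it. Nothing in the available evidence accounts for this result.

All the groups shown on this carbon are built of carbon and hydrogen alone, so it remains open whether an amine or a carboxylic acid there would shift the number in this assay beyond the scatter. Going by these compounds, since all three compounds carry the same long unsaturated chain, it also remains open how a shorter chain in its place would read, and whether the indifference seen at this carbon would hold with it.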